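Fluoro for Chloro in a Set Resting at the Assay Limit

The compounds below may be only part of what the source reports. "The series", "measured", "known", "first", "only" and "open" are said of these compounds alone.

Compound 1 `OC[C@@H]1C[C@H](CO)[C@@H]2C(c3ccccc3Cl)=NO[C@H]12`: in a functional assay on PC-3 cells (Homo sapiens) for cytotoxicity, read by MTT assay, with a stated time of 48 h (on this read-out higher numbers stand for weaker inhibition and lower numbers for stronger inhibition), compound 1 gives > 50 ug/mL, which is a limit.
Compound 2 `COc1ccc(C2=NO[C@@H]3[C@H](CO)C[C@H](CO)[C@H]23)cc1OC`: in this assay compound 2 gives > 50 ug/mL, which is a limit.
Compound 3 `OC[C@@H]1C[C@H](CO)[C@@H]2C(c3ccc(Cl)cc3)=NO[C@H]12`: in this assay compound 3 gives > 50 ug/mL, which is a limit.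

Compound 3 stands exactly where the other two stand: its number is a limit rather than a measured value, so the three compounds cannot be placed in any order against one another. All that can be said of them is the limit of > 50 ug/mL in this assay, at which 3 of the 3 values shown sit. Compound 4 `OC[C@@H]1C[C@H](CO)[C@@H]2C(c3ccc(F)cc3)=NO[C@H]12` differs from compound 3 by fluoro in place of chloro on an aromatic carbon. No step between measured compounds is available, and nothing in this assay gives a reason to think this change would pull a reading that already sits at the limit down into the measurable range. The step that the limit leaves unreadable from compound 3 to compound 4 is therefore expected to be none beyond the scatter. For compound 4 an estimate of 80 ug/mL is given, with a range from 30 ug/mL to 250 ug/mL, and the most likely outcome in this assay is expected to be another limit.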

Compound 4, half-maximal inhibitory concentration: > 50 ug/mL
Compound 4: a limit, no number (the forecaster's own chance of this, stated with the estimate: 85%); the middle value is on the limit's open side.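

Compound 3 and compound 4 both rest at a limit, so fluoro in place of chloro yields no readable step between them: the limit of > 50 ug/mL in this assay, at which 4 of the 4 values shown sit.

The compounds shown leave open how these four rank against one another, and which change to the shared core, if any, would give a measured value.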